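Chloro Substitution on the Pendant Phenyl of a Pyridinone Amide

The compounds below may be only part of what the source reports. "The series", "measured", "known", "first", "only" and "open" are said of these compounds alone.

Measured compounds:
compound 1, `COc1cc2c(Oc3ccc(NC(=O)c4nn(-c5ccccc5)c(=O)cc4C)cc3F)ccnc2cc1OCCCN1CCCC1`, 220 nM
compound 2, `COc1cc2c(Oc3ccc(NC(=O)c4nn(-c5ccc(Cl)cc5)c(=O)cc4C)cc3F)ccnc2cc1OCCCN1CCCC1`, 260 nM
compound 3, `COc1cc2c(Oc3ccc(NC(=O)c4nn(-c5ccc(Cl)cc5)c(=O)cc4C)cc3F)ccnc2cc1OCCCN1CCCCC1`, 360 nM

Of the compounds shown here, three have been measured in a functional assay on HT-29 cells (Homo sapiens) for inhibition, read by MTT assay, with a stated time of 72 h; a higher number here means a weaker inhibitor, a lower number a stronger inhibitor. Compound 1 gives 220 nM, compound 2 gives 260 nM and compound 3 gives 360 nM. The change from compound 1 to compound 2 is chloro in place of hydrogen on an aromatic carbon, and it made a step of a 1.2-fold higher number from compound 1 to compound 2 (0.07 log units; within the scatter). From compound 2 to compound 3 the step was a 1.4-fold higher number from compound 2 to compound 3 (0.14 log units; within the scatter). The difference between the cores of compound 1 and compound 3 is not broken down here.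

Compound 4, `COc1cc2c(Oc3ccc(NC(=O)c4nn(-c5ccc(Cl)cc5Cl)c(=O)cc4C)cc3F)ccnc2cc1OCCCN1CCCCC1`, has not yet been measured. It differs from compound 3 by chloro in place of hydrogen on an aromatic carbon. Among the compounds with values here, this is the same kind of change as the one from compound 1 to compound 2, but its place differs: in compound 4 the entering chloro sits ortho to a large group and meta to a chloro group, whereas in compound 2 it sits para to a large group. Because the earlier step of a 1.2-fold higher number from compound 1 to compound 2 (0.07 log units; within the scatter) was small, a similarly small step is expected here, so compound 4 is estimated at 420 nM in this assay, between 200 nM and 900 nM, meaning an expected step of a 1.2-fold higher number from compound 3 to compound 4 (0.07 log units; within the scatter).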

Compound 4, half-maximal inhibitory concentration: 290 nM
Compound 4: the middle estimate sits 1.4-fold (0.16 log units) above what was measured, within the range that was stated.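

In this assay, chloro in place of hydrogen on the phenyl ring, turning 4-chlorophenyl into 2,4-dichlorophenyl, gave a 1.2-fold lower number from compound 3 to compound 4 (0.09 log units; within the scatter), and set beside the earlier step, the change shows no difference between the two cores that can be told apart: the same change on two cores in this assay, a 1.2-fold higher number (0.07 log units; within the scatter) from compound 1 to compound 2 and a 1.2-fold lower number (0.09 log units; within the scatter) from compound 3 to compound 4, 1.5-fold (0.17 log units) apart, within the scatter of two such steps

So in these two cases, the change left the number within the scatter on both cores, and nothing here separates one direction of step from the other. Within the data shown here, this does not show that chloro is without consequence across the series, since only two pairs are at hand and the entering chloro in compound 4 sits ortho to a large group and meta to a chloro group, a different place from the one it takes in compound 2.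

The compounds shown leave open whether a fluoro, a methoxy or a trifluoromethyl group on the same phenyl ring would behave as chloro does. They also leave open how the change would read with a morpholine in place of the pyrrolidine or piperidine at the end of the chain.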